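Cyclohexyl for sec-butyl on the acylated alpha-carbon

The source may hold more compounds than are shown below. What is called first, only, known or untested is meant among the compounds shown, and "the series" means these compounds.

Within the data shown here, compound 2 `CC[C@@H](C)[C@@H](NC(=O)c1ccccc1)C(=O)N1CCC(c2ccc(Cl)cc2)CC1` has the lowest of the two numbers so far in an assay on THP-1 cells for displacement of a labelled ligand from C-C chemokine receptor type 1 (Homo sapiens); on this read-out lower numbers stand for stronger inhibition and higher numbers for weaker inhibition: compound 2 gives 45 nM. Among the measured compounds shown here, its nearest neighbour is compound 1 `CC[C@@H](NC(=O)c1ccccc1)C(=O)N1CCC(c2ccc(Cl)cc2)CC1`, which in this assay gives 121 nM; the one step between them, a 2.7-fold lower number from compound 1 to compound 2 (0.43 log units; beyond the scatter), is the only measured step that bears on the change considered here. Compound 3 `O=C(N[C@@H](C(=O)N1CCC(c2ccc(Cl)cc2)CC1)C1CCCCC1)c1ccccc1` is not yet measured in this assay. It differs from compound 2 in one place: cyclohexyl in place of sec-butyl on a saturated chain carbon bound to an amide-type nitrogen and a carbonyl carbon. The measured step shows that building out the side chain on this part of the shared core by ethyl in place of hydrogen lowered the number beyond the scatter, and cyclohexyl is a further, larger saturated carbon group at the same position, so compound 3 is expected to give a number near or somewhat below that of compound 2, with the step of a 1.5-fold lower number from compound 2 to compound 3 (0.18 log units; within the scatter) expected to stay modest and possibly within the scatter. The estimate for compound 3 in this assay is 30 nM, within a range from 12 nM to 75 nM.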

Compound 3, half-maximal inhibitory concentration: 121 nM
The estimate for compound 3 lay 4.0-fold (0.61 log units) below the measured number; the measured number lies above the stated range.
By their numbers in this assay, from the lowest: compound 2; then compounds 1 and 3 (each within the scatter of the next).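

In this assay, cyclohexyl in place of sec-butyl on the saturated chain carbon bound to an amide-type nitrogen and a carbonyl carbon gave a 2.7-fold higher number from compound 2 to compound 3 (0.43 log units; beyond the scatter) and so reversed the earlier gain: adding carbon at this position does not by itself lower the number. Cyclohexyl in place of ethyl at the same carbon gave no change at the digits printed from compound 1 to compound 3 (within the scatter) and so left the two compounds within the scatter of each other, which makes sec-butyl the only one of the three groups that stands apart, with compound 2 lowest. Nothing given here accounts for the rise from sec-butyl to cyclohexyl and the reason for it stays unknown.

The compounds shown leave open whether it is the ring of cyclohexyl or its six carbons that goes with the higher number, a question that cyclopentyl, isobutyl or an open chain such as n-hexyl at this carbon could address. They also leave open how a phenyl ring or a chain carrying an amine or a carboxylic acid would fare at this position.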